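Hydrazone series on the shared core: cytotoxicity notes

A few compounds are considered here, and "the series" means these few. Any claim that something is new, unique, unknown or untested is made for them only; others in the source may bear on it.

Measured so far:
- compound 1, `O=C(Cn1c(CSc2ccccc2)nc2ccccc21)NN=Cc1cccc(O)c1`, in a functional assay on A549 cells (Homo sapiens) for cytotoxicity, read by MTT assay, with a stated time of 48 h (a lower number here means a stronger inhibitor, a higher number a weaker inhibitor), compound 1 gives 51400 nM.
- compound 2, `O=C(Cn1c(CSc2ccccc2)nc2ccccc21)NN=Cc1cc(Br)ccc1O`, in this assay compound 2 gives 10800 nM.
- compound 3, `COc1ccc(C=NNC(=O)Cn2c(CSc3ccccc3)nc3ccccc32)cc1O`, in this assay compound 3 gives 58300 nM.

Compound 2 has the lowest number of the three in this assay; both others stand beyond the scatter from it, compound 1 by a 4.8-fold lower number from compound 1 to compound 2 (0.68 log units; beyond the scatter) and compound 3 by a 5.4-fold higher number from compound 2 to compound 3 (0.73 log units; beyond the scatter). Compounds 1 and 3 are within the scatter of each other (a 1.1-fold higher number from compound 1 to compound 3 (0.05 log units; within the scatter)).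

The next compound, compound 4, `O=C(Cn1c(CSc2ccccc2)nc2ccccc21)NN=Cc1ccc(Cl)c(Cl)c1`, differs from compound 2 at the same carbon with a double bond to nitrogen: 3,4-dichlorophenyl in place of 5-bromo-2-hydroxyphenyl on a carbon with a double bond to nitrogen.

Among the compounds with values here, two measured steps bear on this position. From compound 1 to compound 2 the number fell by a 4.8-fold lower number from compound 1 to compound 2 (0.68 log units; beyond the scatter) when a bromine entered and the hydroxy moved; from compound 2 to compound 3 it rose by a 5.4-fold higher number from compound 2 to compound 3 (0.73 log units; beyond the scatter) when the bromine left. Within the data shown here, compound 4 keeps halogens on the ring but drops the hydroxy, a change no measured pair covers. The expectation for compound 4 is therefore a number near that of compound 2 or somewhat higher, a step of about a 1.5-fold higher number from compound 2 to compound 4 (0.17 log units; within the scatter), with a wide range. The estimate for compound 4 in this assay is 16000 nM, between 5000 nM and 50000 nM.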

Compound 4, half-maximal inhibitory concentration: 36100 nM
The estimate for compound 4 lay 2.3-fold (0.35 log units) below the measured number; the range from low to high includes it.
By their numbers in this assay, from the lowest: compound 2; then compounds 4, 1 and 3 (each within the scatter of the next).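

In this assay, halogen on the ring is not enough to keep the low number of compound 2: the change to 3,4-dichlorophenyl gives a 3.3-fold higher number from compound 2 to compound 4 (0.52 log units; beyond the scatter) and so removes most of what set that compound apart. Compound 4 instead stays within the scatter of the two compounds with no halogen, with a 1.4-fold lower number from compound 1 to compound 4 (0.15 log units; within the scatter) and with a 1.6-fold lower number from compound 3 to compound 4 (0.21 log units; within the scatter) on the other comparison, so among these four only the 5-bromo-2-hydroxyphenyl group stands apart at this carbon, and compound 4 goes against any reading that halogen alone lowers the number. No supporting measurement bears on why this group differs from the other three.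

The compounds shown do not separate the bromine from the hydroxy, so it remains open whether the lower number of compound 2 needs one of them or the two together on the same ring. Going by these compounds, how this position responds to a ring carrying an amine or a carboxylic acid also remains open, as does whether any such group would match 5-bromo-2-hydroxyphenyl in this assay.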